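The compounds below may be only part of what the source reports. "The series", "measured", "known", "first", "only" and "open" are said of these compounds alone.

Of the compounds shown here, two built on the same bicyclic core have been measured so far. Compound 1 `CCCCNC(=O)C1C(C(=O)O)[C@@H]2CC[C@H]1O2` carries a butyl group on its amide nitrogen, and compound 2 `O=C(O)C1C(C(=O)Nc2ccc(Br)cc2)[C@H]2CC[C@@H]1O2` carries an aromatic group instead. In an ADME assay on BE(2)-C cells (Homo sapiens) for cytotoxicity, read by MTT assay, with a stated time of 72 h (a lower number here means a stronger inhibitor of growth, a higher number a weaker inhibitor of growth), compound 1 gives 10000 nM, and in this assay compound 2 gives 10000 nM. Compound 1 therefore stands level with compound 2 at the digits shown, the two values falling within the usual scatter of this measurement, so neither can be called the stronger of the pair.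

The next compound, compound 3 `CCCCCCCCNC(=O)C1C(C(=O)O)[C@@H]2CC[C@H]1O2`, differs from compound 1 in one place: butyl in place of hydrogen on a saturated chain carbon, four bonds along the chain from an amide-type nitrogen. Among the measured compounds shown here, no step between two measured compounds of this kind is available to guide the expectation, so the direction and size of the change rest on judgement alone. A modest step toward a lower number in this assay is expected, though one that may not exceed the scatter. For compound 3 the expected result in this assay is 5000 nM, with a range from 1500 nM to 20000 nM, which corresponds to an expected step of a 2.0-fold lower number from compound 1 to compound 3 (0.30 log units; within the scatter).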

Compound 3, concentration for 50% growth inhibition: 10000 nM
Estimate against measurement, compound 3: 2.0-fold (0.30 log units) below, within the range that was stated.
By their numbers in this assay, from the lowest: compounds 1, 2 and 3 (each within the scatter of the next).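

Placing butyl in place of hydrogen on a saturated chain carbon, four bonds along the chain from an amide-type nitrogen, gives no change at the digits printed from compound 1 to compound 3 (within the scatter) in this assay. Among the compounds shown here, this is the first step in the set that compares two compounds differing in one place, and it shows that this position accepts 4 more carbon atoms without a readable difference in growth inhibition, so chain length over this span does not separate compound 1 from compound 3. No measurement is available that would explain this result.

A single step describes only these two chains, so it sets no trend for chain length in general, and a chain other than these two could still read differently. From the compounds shown here alone, whether an amine or a hydroxyl group on this chain, or a methyl ester in place of the carboxylic acid on the shared core, would give a different number in this assay remains open.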